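Epimer at the carbinol carbon of a lactone series

A few compounds are considered here, and "the series" means these few. Any claim that something is new, unique, unknown or untested is made for them only; others in the source may bear on it.

Measured compounds:
Compound 1, `CO[C@@H]1[C@H]2OC(=O)C[C@H]2O[C@@H]1[C@@H](OC)c1ccccc1`, 9240 nM in a functional assay on K562 cells (Homo sapiens) for inhibition, read by MTT assay, with a stated time of 72 h; a lower number here means a stronger inhibitor, a higher number a weaker inhibitor.
Compound 2, `CO[C@@H]1[C@H]2OC(=O)C[C@H]2O[C@@H]1[C@@H](O)c1ccccc1`, 8450 nM.
Compound 3, `CO[C@@H]1[C@H]2OC(=O)C[C@H]2O[C@@H]1C(O)(c1ccccc1)c1ccccc1`, 28700 nM.

Among these three numbers compound 2 gives the lowest, though compound 1 sits within the scatter of it and only compound 3 lies beyond it, with a higher number. Compound 4, `CO[C@@H]1[C@H]2OC(=O)C[C@H]2O[C@@H]1[C@H](O)c1ccccc1`, is the unmeasured partner of compound 2: the two compounds have the same atoms and bonds and differ only in configuration as drawn: 1 of 5 stereo elements differ; a stereocentre at a saturated chain carbon is drawn S in compound 2 and R in compound 4. For the measured compounds named here, no measured step involves a change of configuration alone. Going by the values given here, the one measured step, a 1.1-fold lower number from compound 1 to compound 2 (0.04 log units; within the scatter), concerns a methyl on an oxygen and bears on this change only in showing how little a small alteration at that carbon moved the number. Without any guide to the effect of inverting the stereocentre, the expectation for compound 4 is a step of a 1.2-fold higher number from compound 2 to compound 4 (0.07 log units; within the scatter), with no direction beyond the scatter. Compound 4 is therefore estimated at 10000 nM, within 4000 nM to 25000 nM.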

Compound 4, half-maximal inhibitory concentration: 5360 nM
Compound 4: the middle estimate sits 1.9-fold (0.27 log units) above what was measured, within the range that was stated.
By their numbers in this assay, from the lowest: compounds 4, 2 and 1 (each within the scatter of the next); then compound 3.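

In this assay, for the compounds shown here, the step gives the first direct reading of configuration alone at this carbinol carbon: the fact that compounds 2 and 4 differ only in the configuration as drawn. Inverting this stereocentre gives a 1.6-fold lower number from compound 2 to compound 4 (0.20 log units; within the scatter), so the assay does not separate the two configurations. Like the methyl change at the same oxygen, this change leaves the number within the scatter.

The compounds shown leave open whether the methyl ether behaves the same way when drawn in the R configuration. They also do not show what an amine at this carbon, in place of the oxygen, would give in either configuration.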